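The source may hold more compounds than are shown below. What is called first, only, known or untested is meant among the compounds shown, and "the series" means these compounds.

Working notes on the series.

Compound 3 `O=C(NCc1ccc(S(=O)(=O)c2cccc(C(F)(F)F)c2)cc1)c1cc2cnccc2[nH]1` sits second highest of the three numbers in an ADME assay on microsomes from liver (Homo sapiens) for metabolic stability, read by LC-MS, with a stated time of 30 min, tested at 1 uM (a higher number here means that more of the compound is left, a lower number that less of the compound is left), where compound 3 gives 81%. For the measured compounds named here, its nearest neighbour is compound 1 `O=C(NCc1ccc(S(=O)(=O)c2cc(F)cc(F)c2)cc1)c1cc2cnccc2[nH]1`, for which this assay gives 82%; the step of a number 1 percentage points lower from compound 1 to compound 3 (within the scatter) is the one measured change bearing on this position. Furthest off is compound 2 `O=C(NCc1ccc(S(=O)(=O)c2ccccc2)cc1)c1nc2cnccc2[nH]1`, which in this assay gives 73%, still within the scatter of compound 3.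

The next compound is compound 4 `O=C(NCc1ccc(S(=O)(=O)c2ccccc2)cc1)c1cc2cnccc2[nH]1`. The change from compound 3 is hydrogen in place of trifluoromethyl on an aromatic carbon, a hydrogen in place of trifluoromethyl on an aromatic carbon of a six-membered aromatic ring of carbon only, meta to a large group. Going by the values given here, the only step on this ring so far, a number 1 percentage points lower from compound 1 to compound 3 (within the scatter), was within the scatter, and compound 2, carrying the plain phenyl on the sulfonyl sulfur, also falls within the scatter of compound 3. No step beyond the scatter is therefore expected in this assay; the expected step is a number 4 percentage points lower from compound 3 to compound 4 (within the scatter). For compound 4 the estimate in this assay is 77%, expected between 62% and 90%.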

Compound 4, percent of the compound remaining: 75%
Estimate against measurement, compound 4: 2 percentage points above; the measured number falls inside the stated range.
By their numbers in this assay, from the lowest: compounds 2, 4, 3 and 1 (each within the scatter of the next).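

In this assay taking trifluoromethyl off the ring leaves the number within the scatter (a number 6 percentage points lower from compound 3 to compound 4 (within the scatter)), and the plain phenyl also stays within the scatter of the 3,5-difluorophenyl (a number 7 percentage points lower from compound 1 to compound 4 (within the scatter)), so the three ring patterns on the sulfonyl sulfur in compound 1, compound 3 and compound 4 cannot be told apart here. For the compounds shown here, with the plain phenyl held fixed, the exchange of the group on the carbonyl carbon also falls within the scatter (a number 2 percentage points higher from compound 2 to compound 4 (within the scatter)), the first single-place reading of that part of the molecule. No measurement at hand gives a reason for any of these numbers.

Still open, from the compounds shown here alone, is whether an amine or a carboxylic acid on this ring would give a step beyond the scatter. Also open, going by these compounds, is whether the exchange on the carbonyl carbon reads the same with 3,5-difluorophenyl or 3-(trifluoromethyl)phenyl on the sulfonyl sulfur.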